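This account rests on a few compounds, and the source may have more. Where it says the series, first, only, none or still open, it means among the compounds named here.

This small set shares one core and differs only in the group carried on a saturated chain carbon bound to an amide-type nitrogen in a ring. Compound 1 `CS(=O)(=O)Nc1ccc2c(c1)S(=O)(=O)N=C(C1=C(O)C3CCCC3N(Cc3ccc(F)cn3)C1=O)N2` carries 5-fluoropyridin-2-yl there, and in an ADME assay on Huh-7 cells (Homo sapiens) for cytotoxicity, with a stated time of 72 h (a higher number here means that more compound is tolerated, a lower number that less compound is tolerated), compound 1 gives > 33000 nM, which is a limit of the assay rather than a number. Compound 3 `CS(=O)(=O)Nc1ccc2c(c1)S(=O)(=O)N=C(C1=C(O)C3CCCC3N(CCC3CC3)C1=O)N2` carries cyclopropylmethyl there; in this assay compound 3 gives > 33000 nM, again a limit. The step that the two limits leave unreadable from compound 1 to compound 3 therefore cannot be read. Compound 2 `Cc1cc(CN2C(=O)C(C3=NS(=O)(=O)c4cc(NS(C)(=O)=O)ccc4N3)=C(O)[C@H]3CCC[C@H]32)ccc1F` carries 4-fluoro-3-methylphenyl, and in this assay compound 2 gives > 1000 nM, also a limit. That value sits at the limit of > 1000 nM in this assay, at which 1 of the 3 values shown sits, while compounds 1 and 3 sit at the limit of > 33000 nM in this assay, at which 2 of the 3 values shown sit. Compound 4 `CC(C)CCN1C(=O)C(C2=NS(=O)(=O)c3cc(NS(C)(=O)=O)ccc3N2)=C(O)[C@H]2CCC[C@H]21` is the next compound and differs from compound 2 in that (isobutyl in place of 4-fluoro-3-methylphenyl on a saturated chain carbon bound to an amide-type nitrogen in a ring). Among the measured compounds shown here, the only measured step of the same kind, an aromatic ring giving way to a short saturated chain, is the one from compound 1 to compound 3, and it is unreadable, both of its ends being limits. No number here is expected to signal a change beyond the scatter. Compound 4 is expected to be tolerated up to a similarly high level, with an estimated step that the limit leaves unreadable from compound 2 to compound 4. The estimate for compound 4 is 40000 nM, within a range from 5000 nM to 100000 nM, most likely reported again as a limit.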

Compound 4, half-maximal cytotoxic concentration: > 1000 nM
Compound 4 gave a limit, no number; the forecaster's own chance of this, stated with the estimate: 80%; the middle value lies beyond the limit too.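

In this assay compound 4 gives > 1000 nM, which is a limit and not a number. Compound 2 gives > 1000 nM, also a limit, so the step between compound 2 and compound 4 cannot be read. The compounds shown leave open at what concentration any of the four becomes toxic to the cells, and whether isobutyl in place of 4-fluoro-3-methylphenyl changes that concentration.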